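The source may report more compounds than this note shows. Statements on the series, on what has been measured and on what is new or still open speak of the compounds shown alone.

Compound 3 `COc1ccc(/C=C\C(=O)O)c(OCc2cn(-c3ccccc3C#N)nn2)c1CC=C(C)C` carries a 2-cyanophenyl group on the five-membered ring with three nitrogens. In a functional assay on COLO 205 cells (Homo sapiens) for cytotoxicity, read by MTT assay, with a stated time of 24 h (on this read-out higher numbers stand for weaker inhibition and lower numbers for stronger inhibition), compound 3 gives 3200 nM, the lowest of the two numbers available. Its nearest neighbour is compound 2 `COc1ccc(/C=C\C(=O)O)c(OCc2cn(-c3ccccc3)nn2)c1CC=C(C)C`, which in this assay gives 32300 nM. A third compound, compound 1 `COc1ccc(/C=C\C(=O)O)c(OCc2cn(-c3ccccc3I)nn2)c1CC=C(C)C`, has no result in this assay: for compound 1 the entry reads "not determined" (no result reported).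

Compound 4 `COc1ccc(/C=C\C(=O)O)c(OCc2cn(-c3ccc(NC(C)=O)cc3)nn2)c1CC=C(C)C` differs from compound 3 in one place: 4-acetamidophenyl in place of 2-cyanophenyl on an aromatic nitrogen.

Within the data shown here, only one measured step bears on this, a 10-fold lower number from compound 2 to compound 3 (1.00 log units; beyond the scatter). That step, however, concerns a different group at a different place on the ring, so it does not show directly what an acetamide on the phenyl ring will do. With no further data to anchor the change, the most cautious expectation is a number between those of compound 2 and compound 3. Compound 4 is therefore expected to give 8000 nM in this assay, within 2000 nM to 40000 nM, which means an expected step of a 2.5-fold higher number from compound 3 to compound 4 (0.40 log units; beyond the scatter).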

Compound 4, half-maximal inhibitory concentration: 22600 nM
Compound 4: middle estimate off by 2.8-fold (0.45 log units), on the low side; measured number inside the range.
By their numbers in this assay, from the lowest: compound 3; then compounds 4 and 2 (each within the scatter of the next).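

In this assay, replacing 2-cyanophenyl with 4-acetamidophenyl on the aromatic nitrogen gives a 7.1-fold higher number from compound 3 to compound 4 (0.85 log units; beyond the scatter), so the lower number seen with the nitrile does not extend to every substituted phenyl group at this place. Adding acetamido to the plain phenyl ring gives a 1.4-fold lower number from compound 2 to compound 4 (0.16 log units; within the scatter), a step within the scatter, so the two cannot be told apart in this assay. No measured evidence is available to explain why the two substituted phenyl groups differ. The nitrile and the acetamido group also sit at different places on the phenyl ring, so the compounds shown cannot separate the effect of the group from that of its place. Going by these compounds, it remains open how 4-cyanophenyl or 2-acetamidophenyl would compare, and what an amine or a carboxylic acid on that ring would do.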